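The source may hold more compounds than are shown below. What is called first, only, known or untested is meant among the compounds shown, and "the series" means these compounds.

In a functional assay on SW-620 cells (Homo sapiens) for cytotoxicity, read by MTT assay, with stated times of 4 h and 72 h, tested at 2 uM (on this read-out higher numbers stand for weaker inhibition and lower numbers for stronger inhibition), compound 1 (`COc1ccc(/C=C/C(=O)c2ccc(Nc3cc(C)nc4nc(SCc5nc6ccccc6[nH]5)nn34)cc2)cc1F`) gives 140 nM and compound 2 (`Cc1ccc(/C=C/C(=O)c2ccc(Nc3cc(C)nc4nc(SCc5nc6ccccc6[nH]5)nn34)cc2)cc1`) gives 1520 nM. Compound 3 (`Cc1cc(Nc2ccc(C(=O)/C=C/c3cccc(Cl)c3)cc2)n2nc(SCc3nc4ccccc4[nH]3)nc2n1`) gives 400 nM, the second highest of the three numbers. Compound 4 (`Cc1cc(Nc2ccc(C(=O)/C=C/c3ccccc3Cl)cc2)n2nc(SCc3nc4ccccc4[nH]3)nc2n1`) differs from compound 3 by one change: 2-chlorophenyl in place of 3-chlorophenyl on a double-bonded chain carbon bound to a double-bonded chain carbon. The nearest evidence comes from swaps at that same place: a 2.9-fold higher number from compound 1 to compound 3 (0.46 log units; beyond the scatter), a 3.8-fold lower number from compound 2 to compound 3 (0.58 log units; beyond the scatter) and an 11-fold higher number from compound 1 to compound 2 (1.04 log units; beyond the scatter). For the measured compounds named here, the first two were modest and the last large, but none of them moves the chlorine, so the data offer no direct precedent. No step beyond the scatter is therefore expected, although either direction remains possible. The expected step is a 1.3-fold higher number from compound 3 to compound 4 (0.10 log units; within the scatter). Compound 4 is estimated at 500 nM, with an expected range of 150 nM to 1600 nM.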

Compound 4, half-maximal inhibitory concentration: 680 nM
The estimate for compound 4 lay 1.4-fold (0.13 log units) below the measured number; the measured number falls inside the stated range.
By their numbers in this assay, from the lowest: compound 1; then compounds 3 and 4 (each within the scatter of the next); then compound 2.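

Moving the chlorine from 3-chlorophenyl to 2-chlorophenyl at this place (a 1.7-fold higher number from compound 3 to compound 4 (0.23 log units; within the scatter)) leaves the number within the scatter, the first comparison here that shifts a substituent around the ring without changing it. Compound 4 also joins the 3-chlorophenyl compound in the middle of the series (a 2.2-fold lower number from compound 2 to compound 4 (0.35 log units; beyond the scatter); a 4.9-fold higher number from compound 1 to compound 4 (0.69 log units; beyond the scatter)). Nothing shown accounts for these differences. The compounds shown leave open whether a phenyl ring carrying an amine or a carboxylic acid at this place would give a number nearer that of compound 1 or compound 2.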